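The source may hold more compounds than are shown below. What is called first, only, known or untested is meant among the compounds shown, and "the series" means these compounds.

In an ADME assay on J774.A1 cells (Mus musculus) for cytotoxicity, read by MTT assay, with a stated time of 72 h (a lower number here means that less compound is tolerated, a higher number that more compound is tolerated), compound 1 `COc1ccc(-c2cc(-c3ccc(C4NC(=O)c5ccccc5N4)cc3)nc(N)n2)cc1` gives 178000 nM. For compound 2 `Nc1nc(-c2ccc(F)cc2)cc(-c2ccc(C3NC(=O)c4ccccc4N3)cc2)n1` the result reads "not determined" (no result reported), so compound 2 has no single number and gives no direct baseline. Compound 3 `CN1CCN(c2ccc(-c3cc(-c4ccc(C5NC(=O)c6ccccc6N5)cc4)nc(N)n3)cc2)CC1` differs from compound 2 by one change: 4-methylpiperazin-1-yl in place of fluoro on an aromatic carbon, with 4-methylpiperazin-1-yl in place of fluoro on an aromatic carbon. Within the data shown here, no measured step covers this change, so its size remains a judgement. In this assay a moderate downward shift is expected relative to compound 1 at 178000 nM, meaning less compound tolerated. For compound 3 the estimated value is 50000 nM, with an expected range of 12000 nM to 180000 nM.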

Compound 3, half-maximal cytotoxic concentration: 10200 nM
Compound 3: middle estimate off by 4.9-fold (0.69 log units), on the high side; measured number outside the range, below it.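

In this assay, replacing methoxy with 4-methylpiperazin-1-yl on this aromatic carbon gives a 17-fold lower number from compound 1 to compound 3 (1.24 log units; beyond the scatter) and so shows that the tolerated concentration responds to the group held at this position. No measurement at hand accounts for the step.

Compound 2 has no number, so the fluoro comparison with compound 3 cannot be read. Going by these compounds, whether the step is specific to 4-methylpiperazin-1-yl stays open, and a morpholine, a simple primary amine or a carboxylic acid on the same carbon would bear on that.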